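Aryl substituent swaps on the anilide: cytotoxicity notes

The compounds below may be only part of what the source reports. "The series", "measured", "known", "first", "only" and "open" are said of these compounds alone.

Measured so far in an ADME assay on PC-3 cells (Homo sapiens) for cytotoxicity, read by WST assay, tested at 100 uM; a lower number here means less inhibition, a higher number more inhibition at the concentration tested (going by the name of the read-out):
compound 1 `Cc1nc(-c2cccc(NC(=O)C3CCCN(C(=O)c4cc(C(F)(F)F)cc(C(F)(F)F)c4)C3)c2)cs1`: 1%
compound 2 `C=CCOc1cccc(NC(=O)C2CCCN(C(=O)c3cc(C(F)(F)F)cc(C(F)(F)F)c3)C2)c1`: 0%
compound 3 `O=C(Nc1cccc(-c2cnco2)c1)C1CCCN(C(=O)c2cc(C(F)(F)F)cc(C(F)(F)F)c2)C1`: 9%

All three share the same core and differ only in the group on one aromatic carbon. Compound 3 carries the highest of the three numbers, but its separation from the others is within the scatter: a number 8 percentage points higher from compound 1 to compound 3 (within the scatter) and a number 9 percentage points higher from compound 2 to compound 3 (within the scatter). The remaining step is likewise flat: a number 1 percentage points lower from compound 1 to compound 2 (within the scatter). None of the three exchanges at this position moved the read-out beyond the scatter.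

Compound 4 `O=C(Nc1cccc(Oc2ccccc2)c1)C1CCCN(C(=O)c2cc(C(F)(F)F)cc(C(F)(F)F)c2)C1` is the next exchange at the same aromatic carbon: phenoxy in place of 1,3-oxazol-5-yl on an aromatic carbon. The three measured steps all bear on it, since each replaces the group on that carbon, and each was within the scatter. Compound 4 is therefore expected to sit in the same low region, with a step from compound 3 of about a number 4 percentage points lower from compound 3 to compound 4 (within the scatter), not beyond the scatter. The estimate for compound 4 is 5%, with a range of 0% to 15%.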

Compound 4, a percentage reported as inhibition, at one concentration (the size of the read-out at that concentration, not a potency): 1%
Beside the measured number, compound 4's estimate is 4 percentage points above it, within the range that was stated.
By their numbers in this assay, from the lowest: compounds 2, 1, 4 and 3 (each within the scatter of the next).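

In this assay, phenoxy brings a carbon-only six-membered aromatic ring onto the aromatic carbon in place of the 1,3-oxazol-5-yl, and the step stays flat (a number 8 percentage points lower from compound 3 to compound 4 (within the scatter)); against the 2-methyl-1,3-thiazol-4-yl, the picture is the same (no change at the digits printed from compound 1 to compound 4 (within the scatter)). New here is an exchange on the oxygen itself, with the ether link kept: phenyl in place of allyl also leaves the read-out within the scatter (a number 1 percentage points higher from compound 2 to compound 4 (within the scatter)). No supporting data are available to explain this flat result.

The compounds shown carry only aromatic rings and an allyl ether at this position, so it remains open whether a primary amine, a carboxylic acid or a longer alkoxy chain on the same carbon would give a step beyond the scatter. Changes to the shared core also remain open.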